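Swapping 3-Nitrophenyl for 4-Methoxyphenyl: What to Expect

The source may report more compounds than this note shows. Statements on the series, on what has been measured and on what is new or still open speak of the compounds shown alone.

Of the compounds shown here, two that share one core have been measured so far in an ADME assay on MCF7-DOX cells (Homo sapiens) for cytotoxicity, read by MTT assay, with a stated time of 48 h; on this read-out higher numbers stand for weaker inhibition and lower numbers for stronger inhibition. Compound 1 `COc1cc(OC)c(C(=O)/C=C/c2cccc(F)c2)c(O)c1CC=C(C)C` gives 45400 nM, and compound 2 `COc1cc(OC)c(C(=O)/C=C/c2cccc([N+](=O)[O-])c2)c(O)c1CC=C(C)C` gives 57000 nM. These two numbers lie within the usual scatter of repeated measurements, so compound 2 cannot be told apart from compound 1.

The next structure is compound 3 `COc1ccc(/C=C/C(=O)c2c(OC)cc(OC)c(CC=C(C)C)c2O)cc1`, which still awaits its measurement. It carries 4-methoxyphenyl in place of 3-nitrophenyl on a double-bonded chain carbon bound to a double-bonded chain carbon.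

Among the measured compounds shown here, only one measured step bears on this change. In a 1.3-fold higher number from compound 1 to compound 2 (0.10 log units; within the scatter), nitro takes the place of fluoro on an aromatic carbon, and that step stays within the scatter. For the measured compounds named here, it is a thin guide, since no measured compound carries a methoxy group on this ring. With so little evidence, no step beyond the scatter is expected in this assay, and no direction can be favoured. The estimated change is a 1.2-fold lower number from compound 2 to compound 3 (0.07 log units; within the scatter), which is too small to read as a real shift. Compound 3 is therefore expected at 48000 nM, with an estimated range from 20000 nM to 100000 nM.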

Compound 3, half-maximal inhibitory concentration: 46900 nM
Compound 3: middle estimate off by 1.0-fold (0.01 log units), on the high side, within the range that was stated.
By their numbers in this assay, from the lowest: compounds 1, 3 and 2 (each within the scatter of the next).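

In this assay, the step of a 1.2-fold lower number from compound 2 to compound 3 (0.08 log units; within the scatter) and the step of a 1.0-fold higher number from compound 1 to compound 3 (0.01 log units; within the scatter) both stay within the scatter, so 4-methoxyphenyl cannot be told apart from either 3-nitrophenyl or 3-fluorophenyl. Among the compounds shown here, the earlier pair compared only two groups that both carry their substituent under the same number in the group's name, whereas compound 3 has a different substituent, methoxy, and a different number, 4, and this still brings no readable shift on a double-bonded chain carbon bound to a double-bonded chain carbon. Nothing at hand offers an explanation for this result.

All three compounds therefore show a flat picture for these groups, but three groups are a small sample and a flat result here says nothing about groups of a different kind. The compounds shown leave open whether an amine or a carboxylic acid on this ring would give a step beyond the scatter, and whether 3-methoxyphenyl or 4-nitrophenyl would separate the effect of the substituent from the effect of its number in the name.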